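Acetamido in Place of Nitro on a Shared Core

The source may report more compounds than this note shows. Statements on the series, on what has been measured and on what is new or still open speak of the compounds shown alone.

Of the compounds shown here, three have been measured in an ADME assay on BHK cells (Mesocricetus auratus) for cytotoxicity, read by MTT assay, with a stated time of 96 h; a higher number here means that more compound is tolerated, a lower number that less compound is tolerated. Compound 1 `Fc1cccc(F)c1-c1nc2cc(C(F)(F)F)ccc2[nH]1` gives only a limit, >= 100000 nM. Compound 2 `O=[N+]([O-])c1ccc(-c2nc3cc(Cl)c(Cl)cc3[nH]2)cc1` likewise gives only a limit, > 100000 nM. Compound 3 `O=C(CN1CCCC1)Nc1ccc(-c2nc3ccccc3[nH]2)cc1` gives a number, 55000 nM. Among the measured compounds shown here, compound 2 thus sits at the limit of > 100000 nM in this assay, at which 1 of the 3 values shown sits, while compound 1 sits at the limit of >= 100000 nM in this assay, at which 1 of the 3 values shown sits, and no step between measured compounds is available to calibrate the change at hand. Compound 4 `CC(=O)Nc1ccc(-c2nc3cc(Cl)c(Cl)cc3[nH]2)cc1` differs from compound 2 by acetamido in place of nitro on an aromatic carbon. For the measured compounds named here, with no measured step to lean on, a change from compound 2 to compound 4 of no more than the usual scatter is expected, in either direction. For compound 4 the estimate in this assay is 80000 nM, expected between 30000 nM and 200000 nM, implying an expected step of an at least 1.2-fold lower number from compound 2 to compound 4 (0.09 log units; that floor lies within the scatter).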

Compound 4, half-maximal cytotoxic concentration: > 100000 nM
Compound 4: a limit, no number (the forecaster's own chance of this, stated with the estimate: 55%); middle value at least 1.2-fold (0.09 log units) from the limit.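

Compound 2 and compound 4 both give only limits in this assay, so no step can be read between them. The compounds shown leave open whether acetamido in place of nitro changes the tolerated concentration at all.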